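Side-chain swaps on a shared core: toward compound 4

A few compounds are considered here, and "the series" means these few. Any claim that something is new, unique, unknown or untested is made for them only; others in the source may bear on it.

In a functional assay on the whole organism (Tail, strain ICR) with Mus musculus as the target, in the tail flick test, with a stated time of 60 min, at a dose of 25 umol/kg by the oral route (a higher number here means a stronger effect of the compound at the dose given, a lower number a weaker effect), compound 1 `C[C@H](NC(=O)CN(c1nc(Cl)nc2[nH]cnc12)C1CC1)C(=O)OCc1ccccc1` gives 64.3%.
In this assay compound 2 `C[C@@H](O)[C@H](NC(=O)CN(c1nc(Cl)nc2[nH]cnc12)C1CC1)C(=O)OCc1ccccc1` gives 29.7%.
In this assay compound 3 `NCCCC[C@H](NC(=O)CN(c1nc(Cl)nc2[nH]cnc12)C1CC1)C(=O)OCc1ccccc1` gives 41.2%.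

Compound 3 stands second highest of the three numbers: a number 23.1 percentage points lower from compound 1 to compound 3 (beyond the scatter), and a number 11.5 percentage points higher from compound 2 to compound 3 (beyond the scatter).

Compound 4 `CSCC[C@H](NC(=O)CN(c1nc(Cl)nc2[nH]cnc12)C1CC1)C(=O)OCc1ccccc1` differs from compound 3 in one place: methylsulfanyl in place of 2-aminoethyl on a saturated chain carbon, three bonds along the chain from an amide-type nitrogen and a carbonyl carbon. Going by the values given here, no measured pair makes this exact exchange, so the steps that bear on it are only those at the same chain carbon. a number 34.6 percentage points lower from compound 1 to compound 2 (beyond the scatter) and a number 23.1 percentage points lower from compound 1 to compound 3 (beyond the scatter) both read lower when the methyl of compound 1 is replaced by a chain carrying a hydrogen-bond donor, and a number 11.5 percentage points higher from compound 2 to compound 3 (beyond the scatter) is a modest rise between two such donor-bearing chains. Compound 4 carries no hydrogen-bond donor in this position, so the expected direction is a modest rise back toward the number of compound 1, without reaching it, since the chain length of compound 3 is kept: the expected step is a number 10.8 percentage points higher from compound 3 to compound 4 (beyond the scatter).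

The estimate for compound 4 in this assay is 52%, with a range from 32% to 70%.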

Compound 4, a percentage reported as activity, at one dose (the size of the read-out at that dose, not a potency): 30.8%
Compound 4: middle estimate off by 21.2 percentage points, on the high side; the measured number lies below the stated range.
By their numbers in this assay, from the lowest: compounds 2 and 4 (each within the scatter of the next); then compound 3; then compound 1.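

In this assay, the exchange of 2-aminoethyl for methylsulfanyl gives a number 10.4 percentage points lower from compound 3 to compound 4 (beyond the scatter) and so moves away from compound 1 rather than back toward it; at this chain carbon, losing the hydrogen-bond donor of compound 3 brings no recovery. The comparison with the hydroxyl-bearing side chain gives a number 1.1 percentage points higher from compound 2 to compound 4 (within the scatter) and puts compound 2 and compound 4 level in this assay, even though only compound 2 carries a donor on its side chain, while the comparison with the methyl side chain gives a number 33.5 percentage points lower from compound 1 to compound 4 (beyond the scatter) and shows a large fall with a donor-free chain as well. The presence of a donor therefore does not sort these side chains: compound 2, compound 3 and compound 4 all lie under compound 1, and compound 3, which has an amine, stands above the level pair.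

Nothing available here explains why the methyl side chain of compound 1 stands apart from the other three. Open, on these data alone, is whether the fall follows chain length alone, which a plain unbranched butyl chain or a carboxylic acid at the end of the chain would help to separate from the effect of the terminal atoms.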